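The source may report more compounds than this note shows. Statements on the series, on what has been measured and on what is new or still open speak of the compounds shown alone.

Compounds measured so far in a functional assay on MCF7 cells (Homo sapiens) for inhibition, read by MTT assay, with a stated time of 72 h; on this read-out higher numbers stand for weaker inhibition and lower numbers for stronger inhibition

- compound 1 `Cc1cc2occ(-c3nc(-c4ccccc4)c(-c4ccccc4)n3-c3ccc(Cl)c(Cl)c3)c(=O)c2cc1Cl` gives 1560 nM
- compound 2 `Cc1cccc(-n2c(-c3coc4cc(C)c(Cl)cc4c3=O)nc(-c3ccccc3)c2-c2ccccc2)c1` gives 12500 nM
- compound 3 `Cc1cc2occ(-c3nc(-c4ccccc4)c(-c4ccccc4)n3-c3ccccc3Cl)c(=O)c2cc1Cl` gives 3120 nM

Compound 1 stands at the low end of these numbers, and only compound 3 keeps level with it within the scatter. Compound 4 `Cc1cc2occ(-c3nc(-c4ccccc4)c(-c4ccccc4)n3-c3cccc([N+](=O)[O-])c3)c(=O)c2cc1Cl` has not yet been measured. It carries one structural change: 3-nitrophenyl in place of 3,4-dichlorophenyl on an aromatic nitrogen. In words, 3-nitrophenyl takes the place of 3,4-dichlorophenyl on an aromatic nitrogen.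

Two measured steps replace the same group. With 2-chlorophenyl the result is a 2.0-fold higher number from compound 1 to compound 3 (0.30 log units; within the scatter), and with 3-methylphenyl it is an 8.0-fold higher number from compound 1 to compound 2 (0.90 log units; beyond the scatter). Both go towards higher numbers, though only the second lies beyond the scatter. Among the compounds with values here, no measured compound carries 3-nitrophenyl, so these steps give only a rough guide. A step in the same direction, falling between those two in size, seems most likely in this assay. The expected change is a 2.6-fold higher number from compound 1 to compound 4 (0.41 log units; beyond the scatter). For compound 4 the estimated value is 4000 nM, with an expected range from 1300 nM to 12500 nM.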

Compound 4, half-maximal inhibitory concentration: 1560 nM
Beside the measured number, compound 4's estimate is 2.6-fold (0.41 log units) above it; the measured number falls inside the stated range.
By their numbers in this assay, from the lowest: compounds 1, 4 and 3 (each within the scatter of the next); then compound 2.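

In this assay, 3-nitrophenyl on the aromatic nitrogen holds level with 3,4-dichlorophenyl, with no change at the digits printed from compound 1 to compound 4 (within the scatter), and with 2-chlorophenyl, with a 2.0-fold lower number from compound 3 to compound 4 (0.30 log units; within the scatter), so a group without chlorine and with hydrogen-bond acceptors can stand here with no loss beyond the scatter. The same comparison does not hold for 3-methylphenyl: an 8.0-fold lower number from compound 2 to compound 4 (0.90 log units; beyond the scatter), which shows that the group on this phenyl ring matters and not merely the presence of one. Nothing available here explains why nitro and methyl part so clearly.

The compounds shown leave open whether an amine or a carboxylic acid in place of the nitro group would keep the number near that of compound 4. They also leave open how a plain unsubstituted phenyl group on this nitrogen would compare.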